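The source may report more compounds than this note shows. Statements on the series, on what has been measured and on what is new or still open speak of the compounds shown alone.

Among the measured compounds shown here, compound 3 `COc1ccc(Sc2nc3cc(N)cc(N)c3nc2-c2ccccc2)cc1` gives 26300 nM in a functional assay on SW-620 cells (Homo sapiens) for inhibition, read by sulforhodamine B assay, with a stated time of 48 h (on this read-out lower numbers stand for stronger inhibition of growth and higher numbers for weaker inhibition of growth), the highest of the three numbers known; compound 1 `CCOC(=O)[C@H](CCC(=O)O)NC(=O)c1ccc(Sc2nc3cc(N)cc(N)c3nc2-c2ccccc2)cc1` gives 11700 nM and compound 2 `Nc1cc(N)c2nc(-c3ccccc3)c(NCc3ccc(F)cc3)nc2c1` gives 2190 nM. Compound 4 `Nc1cc(N)c2nc(-c3ccccc3)c(Oc3ccc(F)cc3)nc2c1` differs from compound 3 by 4-fluorophenoxy in place of (4-methoxyphenyl)sulfanyl on an aromatic carbon. For the measured compounds named here, the only measured step that bears on this aromatic carbon is a 12-fold higher number from compound 2 to compound 3 (1.08 log units; beyond the scatter), where a (4-fluorobenzyl)amino group gave way to the (4-methoxyphenyl)sulfanyl group now leaving. Compound 4 keeps the fluorine of compound 2 but carries a phenoxy link instead, so that step bears only partly. A moderate fall in the number is therefore expected, a 2.6-fold lower number from compound 3 to compound 4 (0.42 log units; beyond the scatter). Compound 4 is estimated at 10000 nM, with a range from 3000 nM to 30000 nM.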

Compound 4, concentration for 50% growth inhibition: 19500 nM
Estimate against measurement, compound 4: 2.0-fold (0.29 log units) below, and the stated range covers the measured number.
By their numbers in this assay, from the lowest: compound 2; then compounds 1, 4 and 3 (each within the scatter of the next, the first and the last beyond it).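

In this assay, 4-fluorophenoxy in place of (4-methoxyphenyl)sulfanyl gives a 1.3-fold lower number from compound 3 to compound 4 (0.13 log units; within the scatter) and so leaves the number within the scatter at this aromatic carbon. The (4-fluorobenzyl)amino group stays apart, with an 8.9-fold higher number from compound 2 to compound 4 (0.95 log units; beyond the scatter), although compound 2 and compound 4 both carry the fluorine. Nothing available explains this gap. Still open, on these data alone, is whether the gap follows the nitrogen link or the extra carbon of the benzyl group. A benzyloxy group or a 4-fluoroanilino group at this position would separate the two.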